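The source may hold more compounds than are shown below. What is called first, only, known or untested is meant among the compounds shown, and "the series" means these compounds.

Compound 1 `Cc1ccc(CCCN2CCc3nc(C)c([C@H](OC(C)(C)C)C(=O)O)c(-c4cc(F)c5c(c4C)CCCO5)c3C2)cc1F` gives in an ADME assay on MT2 cells (Homo sapiens) for cytotoxicity, read by XTT assay, with a stated time of 4 days (a higher number here means that more compound is tolerated, a lower number that less compound is tolerated), only the limit > 40000 nM.
Compound 2 `Cc1nc2c(c(-c3cc(F)c4c(c3C)CCCO4)c1[C@H](OC(C)(C)C)C(=O)O)CN(CCCc1ccccc1F)CC2` gives in this assay only the limit > 40000 nM.

Compound 2 stands at the limit of this assay, and its value is not a number but the edge of what the assay reports; this is also where every value shown sits, as the limit of > 40000 nM in this assay, at which 2 of the 2 values shown sit, states. Among the compounds with values here, the one step joining the two measured compounds, a step that the two limits leave unreadable from compound 1 to compound 2, has a size that the two limits leave unreadable, so it gives no scale for any change.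

Compound 3 `Cc1ccccc1CCCN1CCc2nc(C)c([C@H](OC(C)(C)C)C(=O)O)c(-c3cc(F)c4c(c3C)CCCO4)c2C1` is the next compound to be measured. It differs from compound 2 only in this way: methyl in place of fluoro on an aromatic carbon. Within the data shown here, no measured step addresses a change of this kind, and the single step on record cannot be read, so there is no ground to expect a move in either direction beyond the scatter. The most natural expectation is therefore that compound 3 again reaches the limit of this assay, with the step of a number no higher from compound 2 to compound 3 (the limit leaves the size open) expected to be flat. On that basis compound 3 is estimated at 40000 nM in this assay, between 20000 nM and 80000 nM.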

Compound 3, half-maximal cytotoxic concentration: > 40000 nM
Compound 3: no number, only a limit; the forecaster's own chance of this, stated with the estimate: 85%; the middle value lies on the limit itself.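

In this assay compound 3 gives > 40000 nM and this is a limit of the assay, not a number. The steps joining compound 3 to compound 1 and compound 2 therefore cannot be read. The compounds shown leave open how much of each compound the cells tolerate, and whether any change between them alters it: the limit of > 40000 nM in this assay, at which 3 of the 3 values shown sit.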